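Extending the ethyl chain of compound 3 with an ester

A few compounds are considered here, and "the series" means these few. Any claim that something is new, unique, unknown or untested is made for them only; others in the source may bear on it.

In a functional assay (aorta) for inhibition, with Rattus norvegicus as the target (on this read-out higher numbers stand for weaker inhibition and lower numbers for stronger inhibition), compound 1 `C/N=C(\S)[C@]1(c2ccc(Cl)c(Cl)c2)CCCC[S+]1[O-]` gives 300 nM, compound 2 `C/N=C(\S)[C@]1(c2ccccc2)CCCC[S+]1[O-]` gives 9500 nM and compound 3 `CC/N=C(\S)[C@]1(c2cccnc2)CCCC[S+]1[O-]` gives 300 nM. Compound 3 is therefore level with compound 1, and the number for compound 2 is higher than both, beyond the usual scatter.

The next compound to be read is compound 4 `COC(=O)CC/N=C(\S)[C@]1(c2cccnc2)CCCC[S+]1[O-]`. It differs from compound 3 by methoxycarbonyl in place of hydrogen on a saturated chain carbon, two bonds along the chain from a double-bonded nitrogen. Ethyl thus becomes 2-(methoxycarbonyl)ethyl.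

Within the data shown here, no measured pair isolates a change at this place, so the direction rests on judgement alone. The expected result is a 3.3-fold higher number from compound 3 to compound 4 (0.52 log units; beyond the scatter), a moderate move toward a higher number in this assay, meaning weaker inhibition. For compound 4 the estimated value is 1000 nM, with an expected range of 250 nM to 5000 nM.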

Compound 4, concentration for 90% inhibition: > 30000 nM
Compound 4: a limit, no number; the forecaster's own chance of this, stated with the estimate: 5%; middle value at least 30-fold (1.47 log units) from the limit.
By their numbers in this assay, from the lowest: compounds 1 and 3 (each within the scatter of the next); then compound 2. At a limit, above all of these: compound 4.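

In this assay compound 4 gives > 30000 nM, which is a limit of the assay and not a number. Methoxycarbonyl in place of hydrogen on a saturated chain carbon, two bonds along the chain from a double-bonded nitrogen, gives an at least 100-fold higher number from compound 3 to compound 4 (2.00 log units; beyond the scatter), the first reading of any change at this place in the series. The place is therefore not indifferent to what is attached there, at least for this one extension of ethyl to 2-(methoxycarbonyl)ethyl, and the size of the step is itself bounded by a limit: the limit of > 30000 nM in this assay, at which 1 of the 4 values shown sits.

Still open, on these data alone, is whether the loss goes with the added chain length or with the ester itself, a question a plain butyl chain on the same core would address. A carboxylic acid or a primary amide at the chain end would show whether other groups at this position behave as the methyl ester does.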